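The source may hold more compounds than are shown below. What is called first, only, known or untested is meant among the compounds shown, and "the series" means these compounds.

Measured so far in an ADME assay on microsomes from liver (Rattus norvegicus) for metabolic stability, read by LC-MS, with a stated time of 15 min, tested at 1 uM; a lower number here means that less of the compound is left, a higher number that more of the compound is left:

- compound 1 `Cc1cc(F)cnc1N1CCN(C(=O)CCCc2cccc3cncnc23)[C@@H](C)C1`: "not determined" (no result reported)
- compound 2 `O=C(CCS(=O)(=O)c1cccc2ncsc12)N1CCN(c2ccnc(C(F)(F)F)c2)CC1`: "not determined" (no result reported)
- compound 3 `Cc1cc(F)cnc1N1CCN(C(=O)CCCc2cccc3ncc(CO)cc23)[C@@H](C)C1`: 1%

This series offers little to build on. Compound 2 is the natural starting point, yet for compound 2 the entry reads "not determined" (no result reported), so it has no place on the scale. Compound 1 also lacks a number, with the entry "not determined" (no result reported). Only compound 3 has a number, at 1%.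

Compound 4 `N#Cc1ccc(N2CCN(C(=O)CCS(=O)(=O)c3cccc4ncsc34)CC2)nc1` is still waiting for its measurement. The change is 5-cyanopyridin-2-yl in place of 2-(trifluoromethyl)pyridin-4-yl on an amine nitrogen in a ring.

Within the data shown here, no measured pair shows what such a swap does in this assay. No direction can be argued from the data, so the working expectation is a step no larger than the usual scatter, though with no starting value this is only a default. Compound 3, at 1%, differs from compound 4 in more than one place and is a weak guide, so the range has to stay wide.

For compound 4 the expected value is 25%, with an estimated range from 2% to 65%.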

Compound 4, percent of the compound remaining: 59%
Compound 4: middle estimate off by 34 percentage points, on the low side, and the stated range covers the measured number.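

Compound 2 has no number to set against compound 4 in this assay, so no step can be read between them. What the swap of 2-(trifluoromethyl)pyridin-4-yl for 5-cyanopyridin-2-yl does here stays open, and no measured explanation for the result of compound 4 is at hand.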